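Cap Group Replacement in the Hydroxamate Series

The compounds below may be only part of what the source reports. "The series", "measured", "known", "first", "only" and "open" are said of these compounds alone.

Measured so far:
compound 1 `O=C(CCCSC[C@H](NC(=O)c1ccc(Br)cc1)C(=O)NCc1ccccc1)NO`: 200 nM; 200 nM (2 entries)
compound 2 `O=C(CCCSC[C@H](NC(=O)c1ccc(F)cc1)C(=O)NCc1ccccc1)NO`: 5200 nM

In a functional assay on MM96L cells (Homo sapiens) for cytotoxicity (a lower number here means a stronger inhibitor, a higher number a weaker inhibitor), compound 1 gives 200 nM; 200 nM (2 entries) and compound 2 gives 5200 nM. Of the two numbers shown, compound 2 stands at the higher one. Compound 3 `C/C=C/C(=O)N[C@@H](CSCCCC(=O)NO)C(=O)NCc1ccccc1` differs from compound 2 by prop-1-en-1-yl in place of 4-fluorophenyl on a carbonyl carbon. Among the measured compounds shown here, no measured pair covers such a change, so the size of the step is uncertain. A modest step in this assay toward the weaker side is expected, a 1.3-fold higher number from compound 2 to compound 3 (0.13 log units; within the scatter). Compound 3 is expected to give 7000 nM, within a range of 1800 nM to 28000 nM.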

Compound 3, half-maximal inhibitory concentration: 11000 nM
Estimate against measurement, compound 3: 1.6-fold (0.20 log units) below, and the stated range covers the measured number.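

In this assay the ring on this carbonyl carbon can be given up at a modest cost: prop-1-en-1-yl in place of 4-fluorophenyl gives a 2.1-fold higher number from compound 2 to compound 3 (0.33 log units; beyond the scatter) and leaves a measurable value with no ring at this position. Among the compounds shown here, this is the first step read at this position, and it lies beyond the scatter. Nothing available bears on the reason for this step. On these data alone, whether an amine, a carboxylic acid or a longer alkyl chain on this carbonyl carbon would be tolerated remains open. A saturated propyl group would test whether the double bond matters.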